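The source may report more compounds than this note shows. Statements on the series, on what has been measured and on what is new or still open speak of the compounds shown alone.

Measured so far:
- compound 1 `CN(c1ccn(C)n1)c1cnc(NCc2c(F)ccc3c2CCO3)c2cn[nH]c(=O)c12`: 62 mL.min-1.g-1
- compound 2 `Cc1cc(-c2cnc(NCc3c(F)ccc4c3CCO4)c3cn[nH]c(=O)c23)n(C)n1`: 24 mL.min-1.g-1
- compound 3 `Cn1cc(-c2cnc(NCc3c(F)ccc4c3CCO4)c3cn[nH]c(=O)c23)cn1`: 21 mL.min-1.g-1

In an ADME assay on microsomes from liver (Homo sapiens) for metabolic stability, read by LC-MS, using NADPH, with stated times of 5 min and 30 min, tested at 1 uM (a lower number here means slower removal, a higher number faster removal of the compound), compound 1 stands highest of the three numbers; compound 2 sits nearest and compound 3 furthest, both beyond the scatter. The step from compound 1 to compound 4 `CNC(=O)c1cc(-c2cnc(NCc3c(F)ccc4c3CCO4)c3cn[nH]c(=O)c23)n(C)n1` is 1-methyl-3-(methylcarbamoyl)-1H-pyrazol-5-yl in place of methyl(1-methyl-1H-pyrazol-3-yl)amino on an aromatic carbon.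

Among the measured compounds shown here, two measured steps bear on it, since each also removes the methyl(1-methyl-1H-pyrazol-3-yl)amino group from compound 1 and puts a directly attached pyrazolyl ring in its place: a 2.6-fold lower number from compound 1 to compound 2 (0.41 log units; beyond the scatter) and a 3.0-fold lower number from compound 1 to compound 3 (0.47 log units; beyond the scatter). The pair of directly attached pyrazolyl compounds differ little from one another, a 1.1-fold lower number from compound 2 to compound 3 (0.06 log units; within the scatter), so the choice of substituent on that ring has so far mattered less than the change of attachment. For the measured compounds named here, compound 4 carries the same attachment as compound 2 with a methylcarbamoyl group on the ring; no measured pair isolates that carbamoyl, so the expectation leans on the two steps above. A modest lowering is expected, a 3.1-fold lower number from compound 1 to compound 4 (0.49 log units; beyond the scatter), in this assay. Compound 4 is therefore estimated at 20 mL.min-1.g-1, within 10 mL.min-1.g-1 to 40 mL.min-1.g-1.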

Compound 4, intrinsic clearance in microsomes: < 3 mL.min-1.g-1
Compound 4: only a limit was reported; the forecaster's own chance of this, stated with the estimate: 10%; at least 6.6-fold (0.82 log units) between middle value and limit.
By their numbers in this assay, from the lowest: compounds 3 and 2 (each within the scatter of the next); then compound 1. At a limit, below all of these: compound 4.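

Compound 4 is reported in this assay only as a limit: the limit of < 3 mL.min-1.g-1 in this assay, at which 1 of the 4 values shown sits. The substituent on the directly attached pyrazolyl ring now matters at this position, which compound 2 and compound 3 did not show: methylcarbamoyl in place of methyl gives an at least 8.0-fold lower number from compound 2 to compound 4 (0.90 log units; beyond the scatter). The full replacement of methyl(1-methyl-1H-pyrazol-3-yl)amino gives an at least 20-fold lower number from compound 1 to compound 4 (1.31 log units; beyond the scatter), well past what the change of attachment gave alone, and the comparison with the other directly attached pyrazolyl gives an at least 7.0-fold lower number from compound 3 to compound 4 (0.84 log units; beyond the scatter).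

Going by these compounds, how far under the limit compound 4 lies stays open, so each of these steps has only a minimum size. Also open, on these data alone, is whether the amide hydrogen is needed, or whether a dimethylamide, a primary carboxamide, a carboxylic acid or a nitrile in place of methylcarbamoyl would give a similar lowering.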